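Restoring an amine to the amide side chain of compound 3

The source may report more compounds than this note shows. Statements on the series, on what has been measured and on what is new or still open speak of the compounds shown alone.

Three compounds share one core and differ only in the chain attached to the amide nitrogen. Compound 1 `CCn1c(C(=O)NCCCN(C)C)ccc1C(CC)(CC)c1ccc(OCCC(O)(CC)CC)c(C)c1` gives 5 nM in an assay on cells for agonist activity at vitamin D3 receptor (Homo sapiens), with a stated time of 96 h; a higher number here means that more compound is needed for the effect, a lower number that less compound is needed. Compound 2 `CCN(CC)CCNC(=O)c1ccc(C(CC)(CC)c2ccc(OCCC(O)(CC)CC)c(C)c2)n1CC` gives 2.3 nM. Compound 3 `CCn1c(C(=O)NCC#N)ccc1C(CC)(CC)c1ccc(OCCC(O)(CC)CC)c(C)c1` gives 1080 nM, the highest of the three numbers: a 220-fold higher number from compound 1 to compound 3 (2.33 log units; beyond the scatter), and a 470-fold higher number from compound 2 to compound 3 (2.67 log units; beyond the scatter). In both of those steps an amine-bearing chain was replaced by cyano, and the number rose sharply.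

Compound 4 `CCn1c(C(=O)NCCN)ccc1C(CC)(CC)c1ccc(OCCC(O)(CC)CC)c(C)c1` reverses part of that move: aminomethyl in place of cyano on a saturated chain carbon bound to an amide-type nitrogen. The cyano that accompanied the large rise is gone and an aminomethyl group enters, so the chain again ends in a nitrogen bearing hydrogens, though shorter than the chains of compound 1 and compound 2 and without their alkyl groups. The two steps onto compound 3 were large, so the step back off it is expected to be large and downward in this assay, though not necessarily all the way to the numbers of compound 1 and compound 2. Compound 4 is therefore expected to give about 25 nM, within 4 nM to 150 nM, that is a 43-fold lower number from compound 3 to compound 4 (1.64 log units; beyond the scatter).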

Compound 4, half-maximal effective concentration: 156 nM
Compound 4: the middle estimate sits 6.2-fold (0.80 log units) below what was measured, outside the stated range (above it).
By their numbers in this assay, from the lowest: compound 2; then compound 1; then compound 4; then compound 3.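

In this assay, a chain ending in 2-aminoethyl recovers only part of what the cyanomethyl chain lost (a 6.9-fold lower number from compound 3 to compound 4 (0.84 log units; beyond the scatter)). The comparison with compound 2 is the sharper one, as both compounds carry the same chain length and differ only at the amine nitrogen, where the plain amino group is far less favourable than diethylamino (a 68-fold higher number from compound 2 to compound 4 (1.83 log units; beyond the scatter)). The gap to compound 1 is also large (a 31-fold higher number from compound 1 to compound 4 (1.49 log units; beyond the scatter)), but there chain length and the alkyl groups on nitrogen change together, and no measurement here gives the reason for any of these shifts.

The compounds shown leave open whether a single ethyl group on the amine nitrogen would be enough to close the gap to compound 2. They also leave open whether a longer chain ending in a plain amino group would do the same for compound 1.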